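The compounds below may be only part of what the source reports. "The series", "measured", "known", "first", "only" and "open" are said of these compounds alone.

In a functional assay on HOP-92 cells (Homo sapiens) for inhibition (a lower number here means a stronger inhibitor of growth, a higher number a weaker inhibitor of growth), compound 1 `COc1ccc(-n2cnnc2-c2cc(OC)c(OC)c(OC)c2)cc1` gives < 100000 nM, which is a limit of the assay and not a number. For the measured compounds named here, compound 2 `COc1cc(-c2nncn2-c2ccc(N(C)C)cc2)cc(OC)c1OC` gives 389 nM in this assay, so the one measured step, a step that the limit leaves unreadable from compound 1 to compound 2, has no size to carry over. Compound 3 `COc1ccc(-n2cnnc2-c2cc(OC)c(OC)c(OC)c2)cc1O` differs from compound 1 by hydroxy in place of hydrogen on an aromatic carbon. Only compound 2, at 389 nM, offers a number to lean on, and no direction can be read firmly. The expected step, a step that the limit leaves unreadable from compound 1 to compound 3, is therefore a loose estimate. For compound 3 the estimated value is 300 nM, with an expected range from 20 nM to 5000 nM.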

Compound 3, concentration for 50% growth inhibition: 617 nM
Compound 3: the middle estimate sits 2.1-fold (0.31 log units) below what was measured; measured number inside the range.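

No size can be read for the step between compound 1 and compound 3, because the value of compound 1 is a limit of the assay and not a number: the limit of < 100000 nM in this assay, at which 1 of the 3 values shown sits. The compounds shown leave open how far hydroxy in place of hydrogen on an aromatic carbon shifts growth inhibition.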